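A few compounds are considered here, and "the series" means these few. Any claim that something is new, unique, unknown or untested is made for them only; others in the source may bear on it.

In a functional assay on the whole organism with Mus musculus as the target (on this read-out higher numbers stand for an effect only at larger amounts of compound and lower numbers for an effect already at smaller amounts), three compounds have been measured:

Compound 1 `O=C(/C=C/c1cccc(C(F)(F)F)c1)NCCO`: 117 mg/kg
Compound 2 `CCC(O)CNC(=O)/C=C/c1cccc(C(F)(F)F)c1`: 90 mg/kg
Compound 3 `CN(C)C(=O)/C=C/c1cccc(C(F)(F)F)c1`: > 75 mg/kg

The entry for compound 3, > 75 mg/kg, is a limit and not a number.

Compound 4 `CN1CCN(C(=O)/C=C/c2cccc(C(F)(F)F)c2)CC1` has 4-methylpiperazin-1-yl in place of dimethylamino on a carbonyl carbon. Two measured steps also replace the group on the carbonyl carbon, a step that the limit leaves unreadable from compound 1 to compound 3 and a step that the limit leaves unreadable from compound 2 to compound 3, but neither gives a size. Among the measured compounds shown here, the only readable step, a 1.3-fold lower number from compound 1 to compound 2 (0.11 log units; within the scatter), lies within the scatter. No step beyond the scatter, in either direction, is therefore expected in this assay, and the estimated step is a step that the limit leaves unreadable from compound 3 to compound 4. Compound 4 is expected at about 100 mg/kg, with an estimated range of 50 mg/kg to 200 mg/kg.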

Compound 4, dose for half-maximal effect: > 100 mg/kg
Compound 4 ended at the assay's limit; the forecaster's own chance of this, stated with the estimate: 40%; the middle value sits exactly at the limit.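

In this assay compound 4 gives > 100 mg/kg, which is a limit and not a number. Unlike the earlier replacements on this carbonyl carbon, the 4-methylpiperazin-1-yl change yields a step with a readable floor, an at least 1.1-fold higher number from compound 2 to compound 4 (0.04 log units; that floor lies within the scatter), but it shows no change beyond the scatter. The other steps to compound 4 cannot be read: the limit of > 100 mg/kg in this assay, at which 1 of the 4 values shown sits.

On these data alone, how far the true value of compound 4 lies from its limit remains open. Also open, as far as these compounds go, is how morpholin-4-yl, piperidin-1-yl or an unsubstituted piperazin-1-yl would behave on this carbonyl carbon.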